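Imine replacement of the amino group on the shared core

This account rests on a few compounds, and the source may have more. Where it says the series, first, only, none or still open, it means among the compounds named here.

Measured compounds: compound 1 `COC(=O)C(=O)NC1=C(C#N)C2C(N3CCCC3)CCCCN2C(=O)N1c1ccccc1` gives 86.2% in a functional assay on the whole organism (strain albino) for inhibition, with Rattus norvegicus as the target, read by paw edema, with stated times of 1 h and 3 h, at a dose of 18 mmol/kg by the intraperitoneal route; on this read-out higher numbers stand for a stronger effect at the one dose given and lower numbers for a weaker effect; compound 2 `N#Cc1c2n(c(=O)n(-c3ccccc3)c1=N)CCCCC2N1CCCC1` gives 83.4%; compound 3 `N#CC1=C(N)N(c2ccccc2)C(=O)N2CCCCC(N3CCCC3)C12` gives 79.5%.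

Compound 3 lies within the scatter of both other numbers, so no order among the three is established. Compound 4 `N#CC1=C(/N=C/c2ccc([N+](=O)[O-])cc2)N(c2ccccc2)C(=O)N2CCCCC(N3CCCC3)C12` differs from compound 3 by a group of 11 heavy atoms (7 carbon, 2 nitrogen, 2 oxygen; one six-membered aromatic ring of carbon only) in place of one nitrogen atom, on a double-bonded ring carbon. Among the measured compounds shown here, the only measured step at that amine nitrogen is a number 6.7 percentage points lower from compound 1 to compound 3 (within the scatter), which shows that a large substituent on this nitrogen leaves the paw edema inhibition unchanged within the scatter. On that basis no step beyond the scatter is expected for compound 4, so the estimate for compound 4 is 80% (range 66% to 92%), an expected step of a number 0.5 percentage points higher from compound 3 to compound 4 (within the scatter).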

Compound 4, a percentage reported as inhibition, in the whole organism at one dose (the size of the read-out at that dose, not a potency): 81.3%
Compound 4: middle estimate off by 1.3 percentage points, on the low side, within the range that was stated.
By their numbers in this assay, from the lowest: compounds 3, 4, 2 and 1 (each within the scatter of the next).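

At the double-bonded ring carbon, an imine carrying an aromatic ring replaces the amino group, and this assay gives a number 1.8 percentage points higher from compound 3 to compound 4 (within the scatter). Set against the (methoxycarbonyl)carbonyl amine, the same imine gives a number 4.9 percentage points lower from compound 1 to compound 4 (within the scatter), so a large group with an aromatic ring and no hydrogen-bond donor also leaves the read-out within the scatter. No measurement at hand accounts for this result. Going by these compounds, whether an imine with a methoxy group or an amine in place of the nitro group on its aromatic ring also stays within the scatter remains open.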